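From tert-butyl to cyclopropyl in a fluorophenoxy compound

The source may report more compounds than this note shows. Statements on the series, on what has been measured and on what is new or still open speak of the compounds shown alone.

In a functional assay on BXPC-3 cells (Homo sapiens) for cytotoxicity, read by MTT assay, with a stated time of 72 h (on this read-out higher numbers stand for weaker inhibition and lower numbers for stronger inhibition), compound 1 (`CC(C)(C)c1[nH]cnc1/C=c1\[nH]c(=O)/c(=C/c2cccc(C(=O)c3ccc(F)cc3)c2)[nH]c1=O`) gives 0.6 nM and compound 3 (`CC(C)c1[nH]cnc1/C=c1\[nH]c(=O)/c(=C/c2cccc(C(=O)c3ccc(F)cc3)c2)[nH]c1=O`) gives 0.6 nM under the same conditions. Compound 2 (`CC(C)(C)c1[nH]cnc1/C=c1\[nH]c(=O)/c(=C/c2cccc(Oc3ccc(F)cc3)c2)[nH]c1=O`) has the highest number of the three at 3.2 nM on this scale. Setting 4-fluorophenoxy in place of (4-fluorophenyl)carbonyl on an aromatic carbon gave a 5.3-fold higher number from compound 1 to compound 2 (0.73 log units; beyond the scatter) in that comparison. Hydrogen in place of methyl on a saturated chain carbon gave no change at the digits printed from compound 1 to compound 3 (within the scatter) as the only measured change to the tert-butyl group. Compound 4 (`O=c1[nH]/c(=C\c2nc[nH]c2C2CC2)c(=O)[nH]/c1=C\c1cccc(Oc2ccc(F)cc2)c1`) has cyclopropyl in place of tert-butyl on an aromatic carbon, and the difference is cyclopropyl in place of tert-butyl on an aromatic carbon in full. For the measured compounds named here, no measured compound carries cyclopropyl, and the one change to tert-butyl was measured with a different aromatic group, so this guide is indirect. Little movement is therefore expected, with an estimated 1.1-fold higher number from compound 2 to compound 4 (0.04 log units; within the scatter) and nothing beyond the scatter. For compound 4 the estimated value is 3.5 nM with an expected range from 1.2 nM to 11 nM in this assay once measured.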

Compound 4, half-maximal inhibitory concentration: 9.4 nM
For compound 4 the middle estimate is 2.7-fold (0.43 log units) below the measured one, and the stated range covers the measured number.
By their numbers in this assay, from the lowest: compounds 1 and 3 (each within the scatter of the next); then compound 2; then compound 4.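

In this assay, cyclopropyl in place of tert-butyl on the five-membered aromatic ring gave a 2.9-fold higher number from compound 2 to compound 4 (0.47 log units; beyond the scatter), so with 4-fluorophenoxy in place this position does respond to the group it carries. For the compounds shown here, the only earlier change to tert-butyl, made alongside the (4-fluorophenyl)carbonyl group, gave no change at the digits printed from compound 1 to compound 3 (within the scatter); the two steps differ in both the entering group and the aromatic group, so the comparison cannot say which of these accounts for the contrast. Nothing available explains the higher number of compound 4.

The compounds shown leave open whether cyclopropyl would move the number in the same way alongside the (4-fluorophenyl)carbonyl group. They also leave open where a cyclobutyl group or a plain methyl at this place would fall relative to tert-butyl and cyclopropyl.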